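Ester in place of acid on a thromboxane synthase inhibitor

The compounds below may be only part of what the source reports. "The series", "measured", "known", "first", "only" and "open" are said of these compounds alone.

Compounds measured so far:
compound 1 `CSC(CCC/C=C(\c1ccccc1)c1cccnc1)C(=O)O`: 30 nM
compound 2 `O=C(O)CCCC/C=C(\c1cccnc1)c1cccc(F)c1`: 55 nM
compound 3 `O=C(O)CCCCCCCCC/C=C(/c1ccccc1)c1cccnc1`: 520 nM

In an assay (Equus caballus) for inhibition of Thromboxane-A synthase (Homo sapiens), using microsomes (a lower number here means a stronger inhibitor, a higher number a weaker inhibitor), compound 1 gives the lowest number of the three. Compound 2 lies within the usual scatter of compound 1, so the two cannot be told apart, while compound 3 gives a clearly higher number than compound 1, beyond the scatter.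

Compound 4 `CCOC(=O)CCCC/C=C(\c1ccccc1)c1cccnc1` has not been measured. It differs from compound 1 by (ethoxycarbonyl)methyl in place of carboxy(methylsulfanyl)methyl on a saturated chain carbon, three bonds along the chain from a double-bonded chain carbon. Among the measured compounds shown here, no measured pair shows this change, so its effect is not known. The expectation is a step from compound 1 to compound 4 of a 5.0-fold higher number from compound 1 to compound 4 (0.70 log units; beyond the scatter), towards a higher number, with the estimate for compound 4 of 150 nM and a range from 50 nM to 600 nM.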

Compound 4, half-maximal inhibitory concentration: 600 nM
Compound 4: the middle estimate sits 4.0-fold (0.60 log units) below what was measured; the range from low to high includes it.
By their numbers in this assay, from the lowest: compounds 1 and 2 (each within the scatter of the next); then compounds 3 and 4 (each within the scatter of the next).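

In this assay, putting (ethoxycarbonyl)methyl in place of carboxy(methylsulfanyl)methyl gives a 20-fold higher number from compound 1 to compound 4 (1.30 log units; beyond the scatter), a large loss at this place on the chain even though both groups have the same number of heavy atoms. This one swap removes both the free acid and the methylsulfanyl group, so the step cannot be assigned to either alone. No measurement here explains the loss.

Still open, on these data alone, is which part matters, and whether an amide or a methyl ester at this chain end would behave like the ethyl ester.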